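Moving the nitro group on the sulfonyl aryl ring

The source may hold more compounds than are shown below. What is called first, only, known or untested is meant among the compounds shown, and "the series" means these compounds.

Compound 1 `N#C/C(=C\c1ccccc1OS(=O)(=O)c1ccc([N+](=O)[O-])cc1)C(=O)Nc1nnc(Cc2cccc(F)c2)s1` and compound 2 `N#C/C(=C\c1ccccc1OS(=O)(=O)c1ccccc1[N+](=O)[O-])C(=O)Nc1nnc(Cc2cccc(F)c2)s1` share one core; compound 2 carries 2-nitrophenyl in place of 4-nitrophenyl on a sulfonyl sulfur. In a functional assay on HL-60 cells (Homo sapiens) for inhibition, read by CCK-8 assay, with a stated time of 48 h, tested at 20 uM (a lower number here means less inhibition of growth, a higher number more inhibition of growth at the concentration tested), compound 1 gives 18%, and compound 2 gives 23%, so that a number 5 percentage points higher from compound 1 to compound 2 (within the scatter). Compound 3 `Cc1ccc(Cc2nnc(NC(=O)/C(C#N)=C/c3ccccc3OS(=O)(=O)c3ccc([N+](=O)[O-])cc3)s2)cc1` differs from compound 1 in its core by 4-methylphenyl in place of 3-fluorophenyl on a saturated chain carbon bound to an aromatic carbon; in this assay compound 3 gives 17%, and a number 1 percentage points lower from compound 1 to compound 3 (within the scatter). Compound 4 `Cc1ccc(Cc2nnc(NC(=O)/C(C#N)=C/c3ccccc3OS(=O)(=O)c3ccccc3[N+](=O)[O-])s2)cc1` has not been measured; it differs from compound 3 by 2-nitrophenyl in place of 4-nitrophenyl on a sulfonyl sulfur, the same change that turns compound 1 into compound 2, now made on the core of compound 3. The step from compound 3 to compound 4 is expected to be a number 5 percentage points higher from compound 3 to compound 4 (within the scatter), because the earlier step of a number 5 percentage points higher from compound 1 to compound 2 (within the scatter) stayed small. Compound 4 is therefore estimated at 22%, most likely between 10% and 34%.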

Compound 4, percent growth inhibition at one concentration: 33%
Compound 4: the middle estimate sits 11 percentage points below what was measured; the measured number falls inside the stated range.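

In this assay, 2-nitrophenyl in place of 4-nitrophenyl on the sulfonyl sulfur gives a number 16 percentage points higher from compound 3 to compound 4 (beyond the scatter), and this step cannot be told apart from the earlier one: the same change on two cores in this assay, a number 5 percentage points higher (within the scatter) from compound 1 to compound 2 and a number 16 percentage points higher (beyond the scatter) from compound 3 to compound 4, 11 percentage points apart, within the scatter of two such steps. The change from 3-fluorophenyl to 4-methylphenyl, now read with 2-nitrophenyl in place, gives a number 10 percentage points higher from compound 2 to compound 4 (within the scatter), and it too cannot be told apart from its earlier step: the same change on two cores in this assay, a number 1 percentage points lower (within the scatter) from compound 1 to compound 3 and a number 10 percentage points higher (within the scatter) from compound 2 to compound 4, 11 percentage points apart, within the scatter of two such steps. Both changes thus carried over between these two cores, but two cores do not show that either step keeps its size across the series.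

The compounds shown leave open whether an amine or a carboxylic acid in place of the nitro group would behave alike. They also leave open what a longer chain carrying the 4-methylphenyl would do.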